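Adding a third methoxy group to a pyrazoline sulfonamide

A few compounds are considered here, and "the series" means these few. Any claim that something is new, unique, unknown or untested is made for them only; others in the source may bear on it.

Of the compounds shown here, two share one core and have been tested in a functional assay on NCI-H226 cells (Homo sapiens) for antiproliferative activity, with a stated time of 48 h; a lower number here means that less compound is tolerated, a higher number that more compound is tolerated. Compound 1 `Cc1cc(O)c(C2=NN(c3ccc(S(N)(=O)=O)cc3)C(/C=C/c3ccccc3)C2)cc1Cl` gives 51800 nM in this assay. Compound 2 `COc1ccc(C2CC(c3cc(Cl)c(C)cc3O)=NN2c2ccc(S(N)(=O)=O)cc2)cc1OC` gives 86400 nM. Compound 2 thus holds the higher of the two numbers, but the step of a 1.7-fold higher number from compound 1 to compound 2 (0.22 log units; within the scatter) lies within the scatter, so the two cannot be told apart.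

Compound 3 `COc1ccc(C2CC(c3cc(Cl)c(C)cc3O)=NN2c2ccc(S(N)(=O)=O)cc2)c(OC)c1OC` differs from compound 2 by a single change on the 3,4-dimethoxyphenyl group: methoxy in place of hydrogen on an aromatic carbon. Within the data shown here, only one measured step is available, and it concerns a different change, the exchange of 2-phenylethenyl for 3,4-dimethoxyphenyl, which moved the number by a 1.7-fold higher number from compound 1 to compound 2 (0.22 log units; within the scatter). Among the measured compounds shown here, no measured pair shows what an added methoxy on this group does. Given that the one step seen stays within the scatter, the step from compound 2 to compound 3 is expected to be a 1.1-fold lower number from compound 2 to compound 3 (0.03 log units; within the scatter), with no change beyond the scatter in either direction. For compound 3 in this assay the estimate is 80000 nM, within a range from 30000 nM to 200000 nM.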

Compound 3, concentration lethal to 50% of the cells: 43700 nM
Compound 3: the middle estimate sits 1.8-fold (0.26 log units) above what was measured; the range from low to high includes it.
By their numbers in this assay, from the lowest: compounds 3, 1 and 2 (each within the scatter of the next).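

In this assay, among these compounds, the methoxy group placed on this aromatic carbon, ortho to a large group and ortho to a methoxy group, gives a 2.0-fold lower number from compound 2 to compound 3 (0.30 log units; within the scatter) and so provides the first measured step at this position, one that does not rise above the usual noise of the assay. The exchange of 2-phenylethenyl for 2,3,4-trimethoxyphenyl on the saturated ring carbon gives a 1.2-fold lower number from compound 1 to compound 3 (0.07 log units; within the scatter) and also stays inside that noise, as did the exchange for 3,4-dimethoxyphenyl, so all three compounds remain indistinguishable here. Nothing available explains these numbers or links them to any property of the groups.

The compounds shown leave open whether a different group on this same aromatic carbon, such as an amine, a hydroxyl or a longer alkoxy chain, would produce a step beyond the scatter. They also leave open whether a change elsewhere on the shared core, for instance a carboxylic acid in place of the sulfonamide, would separate one compound from the others in this assay.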